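The compounds below may be only part of what the source reports. "The series", "measured", "known", "first", "only" and "open" are said of these compounds alone.

Three compounds have numbers in a functional assay on a cell-free system (plasma, Oryctolagus cuniculus) for inhibition, with stated times of 5 min, 1 min and 6 min; a higher number here means a weaker inhibitor, a lower number a stronger inhibitor. Compound 1 `CCOC(=O)c1c(C)nc(-c2ccccc2C#N)n1OC` gives 14900 nM, compound 2 `CCOC(=O)c1c(C)nc(-c2ccc(C#N)cc2)n1OC` gives 13400 nM, and compound 3 `CCOC(=O)c1c(C)nc(-c2cccc(C#N)c2)n1OCc1ccccc1` gives 5930 nM, the lowest of the three, with its nearest neighbour being compound 2 and its furthest compound 1. Compound 4 `CCOC(=O)c1c(C)nc(-c2cccc(C#N)c2)n1OCc1cccc(C#N)c1` has not yet been measured. It differs from compound 3 in one place: cyano in place of hydrogen on an aromatic carbon. For the measured compounds named here, no pair of measured compounds shows this same change, so nothing here tells how large a step it brings. The expectation for compound 4 in this assay is therefore a step of a 1.0-fold higher number from compound 3 to compound 4 (0.01 log units; within the scatter), which is no step beyond the scatter. Compound 4 is expected to give 6000 nM, within a range from 2500 nM to 15000 nM.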

Compound 4, half-maximal inhibitory concentration: > 30000 nM
Compound 4 gave a limit, no number (the forecaster's own chance of this, stated with the estimate: 5%); middle value at least 5.0-fold (0.69 log units) away from the limit.
By their numbers in this assay, from the lowest: compound 3; then compounds 2 and 1 (each within the scatter of the next). At a limit, above all of these: compound 4.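

In this assay, the change from benzyl to 3-cyanobenzyl brings an at least 5.0-fold higher number from compound 3 to compound 4 (0.70 log units; beyond the scatter), so this aromatic carbon of the benzyl ring is not indifferent to substitution: cyano here gives a weaker inhibitor. The value for compound 4 is a limit, not a number: the limit of > 30000 nM in this assay, at which 1 of the 4 values shown sits.

Going by these compounds, the full size of the step therefore stays open. Also open, on these data alone, is whether this outcome belongs to cyano itself or would also follow with an amine, a carboxylic acid or a methoxy group on the same carbon.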